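An amino group added to compound 3

The compounds below may be only part of what the source reports. "The series", "measured", "known", "first", "only" and "open" are said of these compounds alone.

In a functional assay on PBMC cells (Homo sapiens) for cytotoxicity (a lower number here means a stronger inhibitor, a higher number a weaker inhibitor), compound 3 (`OC[C@H]1[C@H](CO)S[C@@H]1n1cnc2c(O)ncnc21`) gives > 100000 nM, which is a limit and not a number. Compound 1 (`Nc1nc(O)c2ncn([C@@H]3S[C@H](CO)[C@H]3CO)c2n1`) gives > 100000 nM, also a limit. Compound 2 (`Nc1ncnc2c1ncn2[C@H]1S[C@@H](CO)[C@@H]1CO`) gives > 100000 nM, again a limit. For the measured compounds named here, all the evidence therefore comes down to the limit of > 100000 nM in this assay, at which 3 of the 3 values shown sit, and no compound in the set has a readable potency.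

The change from compound 3 to compound 4 (`Nc1nc(O)c2ncn([C@H]3S[C@@H](CO)[C@@H]3CO)c2n1`) is amino in place of hydrogen on an aromatic carbon, between two ring nitrogen atoms. Going by the values given here, the only measured step in the set that involves an amino group is a step that the two limits leave unreadable from compound 2 to compound 3, and it gives no size to carry over. With nothing measured to suggest a gain, no clear change in either direction is expected, and a further limit is the likely outcome. The expected step is a number no higher from compound 3 to compound 4 (the limit leaves the size open). For compound 4 the estimated value is 100000 nM, with an expected range of 30000 nM to 200000 nM.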

Compound 4, half-maximal inhibitory concentration: > 100000 nM
Compound 4 was reported as a limit; the forecaster's own chance of this, stated with the estimate: 85%; the middle value lies on the limit itself.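

In this assay compound 4 gives > 100000 nM, which is a limit and not a number. Its steps from compound 3 and from compound 1 cannot be read, and the evidence remains: the limit of > 100000 nM in this assay, at which 4 of the 4 values shown sit.

The compounds shown leave open whether the added amino group or the inverted configuration changes potency at all.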